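A nitro group added to compound 1

A few compounds are considered here, and "the series" means these few. Any claim that something is new, unique, unknown or untested is made for them only; others in the source may bear on it.

For the measured compounds named here, in a functional assay on HCT-116 cells (Homo sapiens) for cytotoxicity, read by sulforhodamine B assay, with a stated time of 48 h (on this read-out lower numbers stand for stronger inhibition and higher numbers for weaker inhibition), compound 1 (`CC(=O)n1nc(NC(=O)c2ccccc2)c2c1CN(C(=O)c1ccccc1)C2`) gives 580 nM and sits at the low end of the numbers so far. Compound 2 (`CCC(=O)n1nc(NC(=O)c2ccccc2)c2c1CN(C(=O)c1ccccc1)C2`) gives 1060 nM and cannot be told apart from it, while compound 3 (`CC(C)C(=O)n1nc(NC(=O)c2ccccc2)c2c1CN(C(=O)c1ccccc1)C2`) gives 2020 nM and lies higher. Enlarging the small group on the carbonyl gave a 1.8-fold higher number from compound 1 to compound 2 (0.26 log units; within the scatter) and a 3.5-fold higher number from compound 1 to compound 3 (0.54 log units; beyond the scatter) as its measured steps. Compound 4 (`CC(=O)n1nc(NC(=O)c2ccccc2)c2c1CN(C(=O)c1ccc([N+](=O)[O-])cc1)C2`) keeps that group and changes phenyl to 4-nitrophenyl, with nitro in place of hydrogen on an aromatic carbon. Going by the values given here, no measured step touches this place, so those steps offer only a rough guide to size. In this assay the expected change is an estimated 1.2-fold higher number from compound 1 to compound 4 (0.08 log units; within the scatter) and thus none beyond the scatter. For compound 4 the estimated value is 700 nM (expected range 230 nM to 1700 nM).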

Compound 4, half-maximal inhibitory concentration: 16200 nM
Compound 4: middle estimate off by 23-fold (1.36 log units), on the low side; the measured number lies above the stated range.
By their numbers in this assay, from the lowest: compounds 1, 2 and 3 (each within the scatter of the next, the first and the last beyond it); then compound 4.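

In this assay, for the compounds shown here, nitro in place of hydrogen on the aromatic carbon gives a 28-fold higher number from compound 1 to compound 4 (1.45 log units; beyond the scatter), so this place, which the earlier compounds left unchanged, responds strongly to substitution. This single step is larger than any step seen on changing the small group on the carbonyl. No measurement available here explains the loss.

On these data alone, whether any added group at this place would do the same, or nitro alone, remains open. An amine, a methoxy group or a chlorine atom on the same carbon would separate these two readings.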